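The compounds below may be only part of what the source reports. "The series", "measured", "known", "first", "only" and "open" are said of these compounds alone.

Measured compounds:
compound 1, `Cc1c(C)c2c(c(C)c1O)SCO2`, 290 nM
compound 2, `CCCC1Oc2c(C)c(C)c(O)c(C)c2S1`, 25 nM

In a functional assay on ileum (Cavia porcellus) for inhibition of Polyunsaturated fatty acid 5-lipoxygenase (Homo sapiens) (on this read-out higher numbers stand for weaker inhibition and lower numbers for stronger inhibition), compound 2 gives 25 nM, the lowest of the two numbers recorded; its nearest neighbour is compound 1, which gives 290 nM. Among the compounds with values here, the single measured step, a 12-fold lower number from compound 1 to compound 2 (1.06 log units; beyond the scatter), came from propyl in place of hydrogen on a saturated ring carbon. Compound 3, `CCCCC1Oc2c(C)c(C)c(O)c(C)c2S1`, differs from compound 2 by methyl in place of hydrogen on a saturated chain carbon, three bonds along the chain from a saturated ring carbon, so the same difference, cut one bond further out, reads propyl to butyl. Within the data shown here, only the step from compound 1 to compound 2 bears on this change, and it concerned the appearance of the whole chain rather than its lengthening. Lengthening by a single methyl is therefore expected to give, in this assay, at most a small movement and none that must lie beyond the scatter, with any drift leaning toward a lower number. Compound 3 is accordingly estimated at 18 nM, within 6 nM to 55 nM, which would mean an expected step of a 1.4-fold lower number from compound 2 to compound 3 (0.14 log units; within the scatter).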

Compound 3, half-maximal inhibitory concentration: 59 nM
Compound 3: middle estimate off by 3.3-fold (0.52 log units), on the low side, outside the stated range (above it).
By their numbers in this assay, from the lowest: compound 2; then compound 3; then compound 1.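

In this assay the change from propyl to butyl gives a 2.4-fold higher number from compound 2 to compound 3 (0.37 log units; beyond the scatter) and so shows that the gain seen on adding a chain at this saturated ring carbon does not keep growing as the chain lengthens. Butyl still keeps part of that gain, as a 4.9-fold lower number from compound 1 to compound 3 (0.69 log units; beyond the scatter) makes plain when set against hydrogen at the same place, so the number does not follow chain length in one direction across these three compounds: compound 3 goes against any steady fall. No measurement at hand explains this turn.

The compounds shown leave open whether ethyl would match propyl and whether a longer chain such as pentyl would raise the number further. They also leave open how a branched chain such as isopropyl, or a chain ending in an amine or a carboxylic acid, would read at this carbon.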